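This account rests on a few compounds, and the source may have more. Where it says the series, first, only, none or still open, it means among the compounds named here.

Series notes. Among the compounds with values here, in a functional assay on RBL-2H3 cells (Rattus norvegicus) for inhibition (on this read-out lower numbers stand for stronger inhibition and higher numbers for weaker inhibition), compound 1 `Cc1csc(N/C(S)=N/[C@@H](C)c2cccc3ccccc23)n1` gives 83200 nM, the only actual number among the three measured compounds. Compound 2 `COc1ccc2nc(/N=C(\S)N[C@H](C)c3cccc4ccccc34)sc2c1` gives > 100000 nM, which is a limit of the assay and not a number. Compound 3 `Cc1cccc2sc(N/C(S)=N/[C@H](C)c3cccc4ccccc34)nc12` gives > 100000 nM, again a limit only. Within the data shown here, compound 1 therefore stands alone as the one quantified value, with the remaining two at the limit of > 100000 nM in this assay, at which 2 of the 3 values shown sit. Compound 4 `Cc1ccc(N/C(S)=N/[C@@H](C)c2cccc3ccccc23)nc1` is still unmeasured; it differs from compound 1 by 5-methylpyridin-2-yl in place of 4-methyl-1,3-thiazol-2-yl on an amine nitrogen. Among the measured compounds shown here, no step between measured compounds exists, so the expectation rests on the structural change alone: a step of roughly a 1.0-fold lower number from compound 1 to compound 4 (0.02 log units; within the scatter) is expected, not beyond the usual scatter in either direction. Compound 4 is thus estimated at 80000 nM in this assay, with a range from 30000 nM to 200000 nM.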

Compound 4, half-maximal inhibitory concentration: > 100000 nM
Compound 4 ended at the assay's limit; the forecaster's own chance of this, stated with the estimate: 40%; middle value at least 1.2-fold (0.09 log units) away from the limit.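

In this assay, 5-methylpyridin-2-yl in place of 4-methyl-1,3-thiazol-2-yl on an amine nitrogen gives an at least 1.2-fold higher number from compound 1 to compound 4 (0.07 log units; that floor lies within the scatter), so this change yields no lower number at this position. Compound 4 gives > 100000 nM, which is a limit of the assay and not a number. The step is therefore only a floor, and that floor lies within the scatter, so no loss is established either.

On these data alone, how a carboxylic acid or an amine in place of the methyl of the 4-methyl-1,3-thiazol-2-yl group would read remains open. The true size of this step also stays open because the series sits largely at one limit: the limit of > 100000 nM in this assay, at which 3 of the 4 values shown sit.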